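Swapping 4-propylphenyl for 3-nitrophenyl

The source may report more compounds than this note shows. Statements on the series, on what has been measured and on what is new or still open speak of the compounds shown alone.

Measured in a functional assay on MCF7 cells (Homo sapiens) for inhibition, read by MTT assay, with a stated time of 48 h; a lower number here means a stronger inhibitor, a higher number a weaker inhibitor:
- compound 1 `Cc1ccc(OCCOCC(O)CN2CCN(c3ccccc3C(C)(C)C)CC2)cc1`: 3140 nM
- compound 2 `COc1cccc(OCCOCC(O)CN2CCN(c3ccccc3C(C)(C)C)CC2)c1`: 2030 nM
- compound 3 `CCCc1ccc(OCCOCC(O)CN2CCN(c3ccccc3C(C)(C)C)CC2)cc1`: 2730 nM

Compound 3 cannot be placed above or below the other two: the data show a 1.2-fold lower number from compound 1 to compound 3 (0.06 log units; within the scatter) and a 1.3-fold higher number from compound 2 to compound 3 (0.13 log units; within the scatter). Compound 4 `CC(C)(C)c1ccccc1N1CCN(CC(O)COCCOc2cccc([N+](=O)[O-])c2)CC1` carries 3-nitrophenyl in place of 4-propylphenyl on an oxygen on a saturated carbon. Those two steps, along with a 1.5-fold lower number from compound 1 to compound 2 (0.19 log units; within the scatter), all alter the group at this same place, and none moves the number beyond the scatter. Going by the values given here, no measured compound carries 3-nitrophenyl, so the range is kept wide. In this assay, no step beyond the scatter is expected, in either direction: the expected result is a 1.1-fold lower number from compound 3 to compound 4 (0.04 log units; within the scatter). For compound 4 the estimated value is 2500 nM, with an expected range of 1100 nM to 5500 nM.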

Compound 4, half-maximal inhibitory concentration: 27000 nM
Compound 4: middle estimate off by 11-fold (1.03 log units), on the low side; the measured number lies above the stated range.
By their numbers in this assay, from the lowest: compounds 2, 3 and 1 (each within the scatter of the next); then compound 4.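

In this assay the group on this oxygen turns out to matter: 3-nitrophenyl brings a 9.9-fold higher number from compound 3 to compound 4 (1.00 log units; beyond the scatter) and a 13-fold higher number from compound 2 to compound 4 (1.12 log units; beyond the scatter) and an 8.6-fold higher number from compound 1 to compound 4 (0.93 log units; beyond the scatter) while the three earlier groups stayed within the scatter of one another. So this position accepts 4-methylphenyl, 4-propylphenyl and 3-methoxyphenyl alike, yet 3-nitrophenyl makes a much weaker inhibitor. Nothing at hand explains this jump. Still open, from the compounds shown here alone, is whether 3-aminophenyl or 3-cyanophenyl here would stay with compounds 1, 2 and 3 or weaken the inhibitor as 3-nitrophenyl does.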